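Adding a Methoxy Group to the Ketone-Side Ring

A few compounds are considered here, and "the series" means these few. Any claim that something is new, unique, unknown or untested is made for them only; others in the source may bear on it.

Measured compounds:
compound 1, `COc1cc(-c2cc(/C=C/C(=O)c3ccc(N)cc3)[nH]n2)cc(OC)c1OC`, -24%
compound 2, `COc1ccc(C(=O)/C=C/c2cc(-c3cc(OC)c(OC)c(OC)c3)n[nH]2)cc1OC`, -76%

Both compounds were tested in a functional assay on MCF7 cells (Homo sapiens) for cytotoxicity, read by sulforhodamine B assay, with a stated time of 48 h, tested at 10 uM; on this read-out lower numbers stand for a stronger effect and higher numbers for a weaker effect at the one concentration tested. Of the two numbers, compound 2 stands lowest, so it shows the stronger effect, with compound 1 giving the higher number; the step of a number 52 percentage points lower from compound 1 to compound 2 (beyond the scatter) lies well beyond the scatter.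

Compound 3, `COc1cc(C(=O)/C=C/c2cc(-c3cc(OC)c(OC)c(OC)c3)n[nH]2)cc(OC)c1OC`, is not yet measured. It differs from compound 2 in one place: methoxy in place of hydrogen on an aromatic carbon. The new methoxy sits on an aromatic carbon of a six-membered aromatic ring of carbon only, ortho to a methoxy group and meta to a large group.

Among the compounds with values here, the only measured step concerns the same ring but a different change, swapping the whole group on the carbonyl carbon, and it was large. Within the data shown here, no measured step isolates the effect of adding one further methoxy to a ring already carrying two. Without such a step, the expectation for compound 3 is a small change, a number 4 percentage points higher from compound 2 to compound 3 (within the scatter), within the scatter, and its value in this assay is estimated at -72%, between -92% and -45%.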

Compound 3, a percentage reported as activity, at one concentration (the size of the read-out at that concentration, not a potency): -85%
Beside the measured number, compound 3's estimate is 13 percentage points above it; the range from low to high includes it.
By their numbers in this assay, from the lowest: compounds 3 and 2 (each within the scatter of the next); then compound 1.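

In this assay the step to the third methoxy, a number 9 percentage points lower from compound 2 to compound 3 (within the scatter), shows that the two numbers cannot be told apart when methoxy takes the place of hydrogen on this aromatic carbon, ortho to a methoxy group and meta to a large group. The earlier step swapped the whole group on the carbonyl carbon, so it could not show what a single added methoxy does on a ring that already carries two; this pair isolates that one change, and the strong effect seen with compound 2 is still present in compound 3. No measurement shown here bears on why this position accepts the extra methoxy without a clear shift in the number.

Still open, from the compounds shown here alone, is what other groups would do at this same carbon, for example a hydroxyl, an amine or a longer chain such as ethoxy, since methoxy and hydrogen are the only two compared here. Also open, going by these compounds, is whether compound 2 and compound 3 would separate at other concentrations, since a reading at a single concentration is not a measure of potency.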